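A few compounds are considered here, and "the series" means these few. Any claim that something is new, unique, unknown or untested is made for them only; others in the source may bear on it.

Measured in a physicochemical assay for solubility, in phosphate buffer, at pH 7.4; on this read-out higher numbers stand for higher solubility and lower numbers for lower solubility:
Compound 1 `CC(=O)N[C@@H]1CCC[C@H](C(=O)Nc2cc(-c3cnc4ccccn34)c(Cl)cn2)C1`: 120000 nM
Compound 2 `CC(=O)N[C@@H]1CCC[C@H](C(=O)Nc2cc(-c3cnn4c3CC(C)(C)C4)c(Cl)cn2)C1`: 150000 nM

With only these two numbers available, compound 2 at 150000 nM stands level with compound 1 within the scatter. Compound 3 `CC(=O)N[C@@H]1CC[C@H](C(=O)Nc2cc(-c3cnn4c3CC(C)(C)C4)c(Cl)cn2)C1` differs from compound 2 in one place: 3-acetamidocyclopentyl in place of 3-acetamidocyclohexyl on a carbonyl carbon. In words, 3-acetamidocyclopentyl replaces 3-acetamidocyclohexyl on a carbonyl carbon, and neither group carries a net charge. Within the data shown here, no step at this carbonyl carbon has been measured. Among the measured compounds shown here, the only measured step, a 1.3-fold higher number from compound 1 to compound 2 (0.10 log units; within the scatter), was made on an aromatic carbon and lies within the scatter, so it bears on this change only indirectly. On that limited evidence, the expected step in this assay is no change at the digits printed from compound 2 to compound 3 (within the scatter), with nothing expected beyond the scatter. The estimate for compound 3 is 150000 nM, with an expected range from 80000 nM to 280000 nM.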

Compound 3, solubility: 35000 nM
For compound 3 the middle estimate is 4.3-fold (0.63 log units) above the measured one; measured number outside the range, below it.
By their numbers in this assay, from the lowest: compound 3; then compounds 1 and 2 (each within the scatter of the next).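

At the carbonyl carbon, 3-acetamidocyclopentyl in place of 3-acetamidocyclohexyl gives, in this assay, a 4.3-fold lower number from compound 2 to compound 3 (0.63 log units; beyond the scatter), the first step shown to lie beyond the scatter. This position therefore registers a change of ring size alone, since the two groups have the same counts of hydrogen-bond donors, acceptors and defined stereocentres, and neither carries a net charge. No measurement available accounts for the step.

The compounds shown leave open whether a cyclobutyl ring or an open chain at this carbonyl carbon would follow the same direction, since only two ring sizes appear here. They also leave open whether a carboxylic acid or an amine in place of the acetamide would change the number in this assay on the cyclopentyl ring of compound 3.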